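This account rests on a few compounds, and the source may have more. Where it says the series, first, only, none or still open, it means among the compounds named here.

Compound 1 `COc1ccccc1NC(=S)N/N=C/c1ccc2ccccc2n1` is one of three compounds whose antiproliferative activity was measured in a functional assay on HeLa cells (Homo sapiens) for antiproliferative activity, read by sulforhodamine B assay, with a stated time of 72 h; on this read-out lower numbers stand for stronger inhibition and higher numbers for weaker inhibition. In that read-out compound 1 gives > 100000 nM, which is a limit of the assay and not a number. Compound 3 `NC(=S)N/N=C/c1cnc2ccccc2n1` gives > 100000 nM in this assay, again a limit rather than a measured number. For the measured compounds named here, the one member with an actual number is compound 2 `CN(C)C(=S)N/N=C/c1cc2cccnc2s1`, which gives 48400 nM in this assay. Compound 1 therefore stands at the limit, and what the set offers on this point is chiefly (the limit of > 100000 nM in this assay, at which 2 of the 3 values shown sit). Going by the values given here, no step between measured compounds that differ in one place is available, so no measured change can be used as a guide.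

Compound 4 `Fc1ccc(NC(=S)N/N=C/c2ccc3ccccc3n2)cc1` is the next member to be measured. It differs from compound 1 in one place: 4-fluorophenyl in place of 2-methoxyphenyl on an amide-type nitrogen. Among the compounds with values here, because compound 1 gives only > 100000 nM, no measured step shows what weight a change on the amide-type nitrogen carries here. Within the usual scatter, no step beyond it is expected in this assay. Compound 4 is expected to sit near the limit as well, with a fair chance that the assay again reports only a limit. The estimate for compound 4 in this assay is 100000 nM, between 30000 nM and 300000 nM. The step expected is a number no higher from compound 1 to compound 4 (the limit leaves the size open).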

Compound 4, half-maximal inhibitory concentration: 33200 nM
Compound 4: the middle estimate sits 3.0-fold (0.48 log units) above what was measured, within the range that was stated.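

In this assay, replacing 2-methoxyphenyl with 4-fluorophenyl on the amide-type nitrogen gives an at least 3.0-fold lower number from compound 1 to compound 4 (0.47 log units; beyond the scatter). For the compounds shown here, this is the first measured sign that the group at this place on the shared core can move the read-out beyond the usual scatter, which the earlier compounds, with no step between them, could not show. The step can only be stated as a minimum because compound 1 gives a limit of the assay rather than a number, so the full weight of the change remains unknown: the limit of > 100000 nM in this assay, at which 2 of the 4 values shown sit.

The compounds shown leave open whether the step comes from the loss of 2-methoxyphenyl or from the arrival of 4-fluorophenyl, as the two groups differ in both the substituent and its place on the ring. Going by these compounds, how a plain phenyl, a 4-chlorophenyl or a 4-methoxyphenyl on the same nitrogen would read in this assay is also open, and any of these would help to separate those two contributions.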